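Benzothiazole hydrazines: cytotoxicity in MT4 cells, bromo to methyl

The compounds below may be only part of what the source reports. "The series", "measured", "known", "first", "only" and "open" are said of these compounds alone.

Measured so far:
compound 1 `NNc1nc2ccc(F)cc2s1` 13.8 ug/mL
compound 2 `NNc1nc2c([N+](=O)[O-])cccc2s1` 14.5 ug/mL
compound 3 `O=[N+]([O-])c1ccc(-c2nnc(-c3cccnc3)n2Nc2nc3ccc(Br)cc3s2)cc1` 13.2 ug/mL

In an ADME assay on MT4 cells (Homo sapiens) for cytotoxicity, read by MTT assay, with a stated time of 5 days (on this read-out lower numbers stand for higher toxicity in this test and higher numbers for lower toxicity in this test), compound 3 gives 13.2 ug/mL, and this sits with the numbers of compound 1 and compound 2, all three within the scatter of each other, so nothing separates them. Going by the values given here, no step between measured compounds is available for the change now considered.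

Compound 4 `Cc1ccc2nc(Nn3c(-c4ccc([N+](=O)[O-])cc4)nnc3-c3cccnc3)sc2c1` is the next member: methyl in place of bromo on an aromatic carbon. The three measured compounds vary at different places yet give alike numbers in this assay, so for this change no step beyond the scatter is expected, in either direction. For compound 4 the expected step from compound 3 is a 1.1-fold higher number from compound 3 to compound 4 (0.03 log units; within the scatter), and the estimate for compound 4 in this assay is 14 ug/mL, with a range from 7 ug/mL to 28 ug/mL.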

Compound 4, half-maximal cytotoxic concentration: 64.4 ug/mL
Estimate against measurement, compound 4: 4.6-fold (0.66 log units) below; the whole stated range lies below it.
By their numbers in this assay, from the lowest: compounds 3, 1 and 2 (each within the scatter of the next); then compound 4.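

In this assay, methyl in place of bromo on an aromatic carbon gives a 4.9-fold higher number from compound 3 to compound 4 (0.69 log units; beyond the scatter), so this one place moves the number beyond the scatter, toward lower toxicity in this test. The earlier compounds shown here, whose numbers lie within the scatter of each other, showed no such sensitivity. Nothing measured here bears on the reason for the step.

As far as these compounds go, whether the step comes from losing bromo or from gaining methyl stays open; chloro, methoxy or an amine on the same carbon would help separate the two. From the compounds shown here alone, whether the change carries over to other members also stays open.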